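The compounds below may be only part of what the source reports. "The series", "measured", "known", "first", "only" and "open" are said of these compounds alone.

In a toxicity assay on L02 cells (Homo sapiens) for cytotoxicity, read by MTT assay, with a stated time of 72 h (a lower number here means a stronger inhibitor, a higher number a weaker inhibitor), the measured compounds are:

- compound 1 `O=C1c2c[n+]([O-])c3ccccc3c2C(=O)c2c1c1ccccc1n2CCN1CCCC1`: 930 nM
- compound 2 `CCCN1CCN(CCCCn2c3c(c4ccccc42)C(=O)c2c[n+]([O-])c4ccccc4c2C3=O)CC1`: 6830 nM
- compound 3 `O=C1c2c[n+]([O-])c3ccccc3c2C(=O)c2c1c1ccccc1n2CCN1CCCCC1`: 1050 nM

Compound 3 lies within the scatter of compound 1, and compound 2 stands well apart from both at 6830 nM. The unmeasured compound 4 `CN1CCN(CCCCCCn2c3c(c4ccccc42)C(=O)c2c[n+]([O-])c4ccccc4c2C3=O)CC1` differs from compound 3 as follows: 4-(4-methylpiperazin-1-yl)butyl in place of piperidin-1-yl on a saturated chain carbon, two bonds along the chain from an aromatic nitrogen. In words, 4-(4-methylpiperazin-1-yl)butyl stands in place of piperidin-1-yl on a saturated chain carbon, two bonds along the chain from an aromatic nitrogen.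

Among the measured compounds shown here, three measured steps bear on this change. Exchanging one small ring for another made little difference, giving a 1.1-fold higher number from compound 1 to compound 3 (0.05 log units; within the scatter). For the measured compounds named here, compound 2 is the only measured compound with a piperazine-bearing group here, and its steps are larger: a 7.3-fold higher number from compound 1 to compound 2 (0.87 log units; beyond the scatter) and a 6.5-fold lower number from compound 2 to compound 3 (0.81 log units; beyond the scatter). A step of modest size towards a higher number is therefore expected in this assay, although this rests on compound 2 alone. The expected change is a 3.3-fold higher number from compound 3 to compound 4 (0.52 log units; beyond the scatter). Compound 4 is estimated at 3500 nM, with an expected range of 1200 nM to 10000 nM.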

Compound 4, half-maximal inhibitory concentration: 3800 nM
For compound 4 the middle estimate is 1.1-fold (0.04 log units) below the measured one; the range from low to high includes it.
By their numbers in this assay, from the lowest: compounds 1 and 3 (each within the scatter of the next); then compounds 4 and 2 (each within the scatter of the next).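

In this assay the higher number seen with compound 2 now has a second example, with a 3.6-fold higher number from compound 3 to compound 4 (0.56 log units; beyond the scatter) and a 4.1-fold higher number from compound 1 to compound 4 (0.61 log units; beyond the scatter) for the exchange of a small ring for a longer piperazine-bearing group on this saturated chain carbon. The two piperazine-bearing groups do not separate, with a 1.8-fold lower number from compound 2 to compound 4 (0.25 log units; within the scatter) when 2-(4-methylpiperazin-1-yl)ethyl stands in place of 4-propylpiperazin-1-yl further along the chain. No measurement here accounts for the higher numbers of these groups.

From the compounds shown here alone, the butyl and ethyl chains and the methyl and propyl end groups change together from compound 2 to compound 4, so the share of each stays open. Also open, going by these compounds, is how a morpholin-4-yl or dimethylamino group would read at this place.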